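Configuration swap at the saturated chain carbon

The source may hold more compounds than are shown below. What is called first, only, known or untested is meant among the compounds shown, and "the series" means these compounds.

Measured in a functional assay on HL-60 cells (Homo sapiens) for cytotoxicity, read by MTT assay, with a stated time of 72 h; a higher number here means a weaker inhibitor, a lower number a stronger inhibitor:
- compound 1 `COc1ccc(C(CC(=O)N[C@@H](CC(C)C)B(O)O)NC(=O)c2ccccc2)cc1`: 1020 nM
- compound 2 `COc1ccc([C@H](CC(=O)N[C@@H](CC(C)C)B(O)O)NC(=O)c2ccccc2)cc1`: 700 nM

For the measured compounds named here, the only measured step is a 1.5-fold lower number from compound 1 to compound 2 (0.16 log units; within the scatter), so compound 2 stands level with its single neighbour in this assay. Compound 3 `COc1ccc([C@@H](CC(=O)N[C@@H](CC(C)C)B(O)O)NC(=O)c2ccccc2)cc1` follows from compound 2: the two compounds have the same atoms and bonds and differ only in configuration as drawn: 1 of 2 stereo elements differ; a stereocentre at a saturated chain carbon is drawn S in compound 2 and R in compound 3. That one step bears on this change, and what it compares is the fact that one of compounds 1 and 2 is drawn with a defined configuration and the other without, at the place where they differ. If compound 1 at 1020 nM holds both configurations, a modestly higher number is expected for the R form, though this inference is weak. The expected change is a 2.6-fold higher number from compound 2 to compound 3 (0.41 log units; beyond the scatter). Compound 3 is estimated at 1800 nM, within an expected range of 750 nM to 4500 nM.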

Compound 3, half-maximal inhibitory concentration: 140 nM
Compound 3: middle estimate off by 13-fold (1.11 log units), on the high side; the whole stated range lies above it.
By their numbers in this assay, from the lowest: compound 3; then compounds 2 and 1 (each within the scatter of the next).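

At this saturated chain carbon, configuration matters in this assay: the change from S to R gives a 5.0-fold lower number from compound 2 to compound 3 (0.70 log units; beyond the scatter), a gap that the earlier pair, whose step lay within the scatter, did not show. The drawing without a configuration also stands apart from the R form, with a 7.3-fold lower number from compound 1 to compound 3 (0.86 log units; beyond the scatter), leaving compound 3 with the lowest number of the three. Only the stereocentre separates the S and R forms: the fact that compounds 2 and 3 differ only in the configuration as drawn

Going by these compounds, what compound 1 holds as drawn stays open. Also open, on these data alone, is whether the R form keeps its lower number with a trifluoromethyl group in place of the methoxy group.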